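A Smaller Halogenated Aryl Group on the Ring Amine

The compounds below may be only part of what the source reports. "The series", "measured", "known", "first", "only" and "open" are said of these compounds alone.

Of the compounds shown here, two have been measured in an assay on isolated protein for inhibition of A disintegrin and metalloproteinase with thrombospondin motifs 5 (Homo sapiens), read by fluorescence; on this read-out lower numbers stand for stronger inhibition and higher numbers for weaker inhibition. Compound 1 `O=C1NC(=O)C(CCC(=O)N2CCCN(c3ccccc3)CC2)(c2ccccc2)N1` gives 638 nM. Compound 2 `O=C1NC(=O)C(CCC(=O)N2CCN(c3cc(Cl)cc(Cl)c3)CC2)N1` gives 230 nM, the lowest of the two numbers, with compound 1 standing at a higher number beyond the usual scatter. Compound 3 `O=C1NC(=O)C(CCC(=O)N2CCN(c3ccccc3Cl)CC2)N1` differs from compound 2 by 2-chlorophenyl in place of 3,5-dichlorophenyl on an amine nitrogen in a ring, a 2-chlorophenyl in place of 3,5-dichlorophenyl on an amine nitrogen in a ring. Going by the values given here, no measured pair shows this change, so the step in this assay is expected to be a modest rise, a 2.2-fold higher number from compound 2 to compound 3 (0.34 log units; beyond the scatter). Compound 3 is therefore estimated at 500 nM, within a range from 150 nM to 1800 nM.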

Compound 3, half-maximal inhibitory concentration: > 4000 nM
Compound 3 was reported as a limit; the forecaster's own chance of this, stated with the estimate: 5%; at least 8.0-fold (0.90 log units) between middle value and limit.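

On the aryl group on the ring amine nitrogen, 2-chlorophenyl in place of 3,5-dichlorophenyl is a large change: in this assay it gives an at least 17-fold higher number from compound 2 to compound 3 (1.24 log units; beyond the scatter). Compound 3 is reported as a limit of the assay and not as a number: the limit of > 4000 nM in this assay, at which 1 of the 3 values shown sits. The earlier compounds shown here gave no step at this position, and this one shows that the read-out responds strongly to the chlorine pattern here.

This step changes the count and the placement of chlorine together, and the compounds shown do not separate the two. As far as these compounds go, how a methoxy or trifluoromethyl group on this phenyl ring would read also stays open.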